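Methyl in place of iodo on the triazole-linked phenyl

A few compounds are considered here, and "the series" means these few. Any claim that something is new, unique, unknown or untested is made for them only; others in the source may bear on it.

Measured so far:
Compound 1, `CC(C)n1ncc2c(C(=O)Nc3cccnc3)cccc21`: > 40000 nM
Compound 2, `CC(C)n1ncc2c(C(=O)NCc3ccccc3)cccc21`: > 40000 nM
Compound 3, `CC(C)n1ncc2c(C(=O)NCc3cn(-c4ccc(I)cc4)nn3)cccc21`: > 40000 nM

All three compounds share one core and were tested in a functional assay on MCF7 cells (Homo sapiens) for inhibition, read by MTT assay, with a stated time of 72 h; on this read-out lower numbers stand for stronger inhibition and higher numbers for weaker inhibition. For compound 1 the value is a limit of the assay, not a number. The same holds for compound 2. For compound 3 the value is again only a limit, so its standing among the numbers shown is simply that it sits at the limit, as do the other two values. The step that the two limits leave unreadable from compound 1 to compound 2 cannot be read because the limit of > 40000 nM in this assay, at which 3 of the 3 values shown sit, hides any difference between the two compounds.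

Compound 4, `Cc1ccc(-n2cc(CNC(=O)c3cccc4c3cnn4C(C)C)nn2)cc1`, differs from compound 3 in one place: methyl in place of iodo on an aromatic carbon. Among the measured compounds shown here, no measured step bears on this change, since every value shown is a limit. Compound 4 is therefore expected to give 60000 nM, with a range from 20000 nM to 200000 nM, most likely reported once more as a limit. The step that the limit leaves unreadable from compound 3 to compound 4 is expected to stay within the scatter.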

Compound 4, half-maximal inhibitory concentration: > 40000 nM
Compound 4 gave a limit, no number; the forecaster's own chance of this, stated with the estimate: 85%; the middle value does not contradict the limit.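

No step can be read between compound 3 and compound 4, because in this assay each gives only a limit, not a number: the limit of > 40000 nM in this assay, at which 4 of the 4 values shown sit.
The compounds shown leave open how iodo and methyl truly compare, and which change to the shared core, if any, would give a measurable value.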